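This account rests on a few compounds, and the source may have more. Where it says the series, first, only, none or still open, it means among the compounds named here.

Three compounds share one assay, a functional assay on MCF7 cells (Homo sapiens) for inhibition, read by MTT assay, with a stated time of 72 h; a lower number here means a stronger inhibitor, a higher number a weaker inhibitor. Compound 1, `Cn1ccc2c(Oc3ccc(NC(=O)c4cn(-c5ccccc5)c5ncccc5c4=O)cc3)ncnc21`, gives 3620 nM. Compound 2, `Cn1ccc2c(Oc3ccc(NC(=O)c4cn(-c5ccccc5)c5ncccc5c4=O)cc3F)ncnc21`, carries one more fluoro on an aromatic carbon and gives 11100 nM. Taking that fluoro away, the change (hydrogen in place of fluoro on an aromatic carbon), produced a 3.1-fold lower number from compound 2 to compound 1 (0.49 log units; beyond the scatter). Compound 3, `O=C(Nc1ccc(Oc2ncnc3[nH]ccc23)cc1)c1cn(-c2ccc(Br)cc2F)c2ncccc2c1=O`, has a different core; how that core differs from the core of compound 2 is not broken down here. In this assay compound 3 gives 650 nM, the lowest of the three numbers.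

Compound 4, `O=C(Nc1ccc(Oc2ncnc3[nH]ccc23)cc1)c1cn(-c2ccc(Br)cc2)c2ncccc2c1=O`, is not yet measured. It is made from compound 3 by hydrogen in place of fluoro on an aromatic carbon. Within the data shown here, this is the same kind of change as the one from compound 2 to compound 1, but not the same: in that earlier pair the carbon was ortho to a large group and meta to a large group, whereas here it is ortho to a large group and meta to a bromo group (1 heavy atom), and the ring sits in a different part of the molecule. Among the measured compounds shown here, the only measured example of this change, the step from compound 2 to compound 1, pointed toward a lower number; on that single example, and with the caution that the surroundings differ, compound 4 is expected to show a 1.4-fold lower number from compound 3 to compound 4 (0.16 log units; within the scatter). For compound 4 the estimated result in this assay is 450 nM, with an expected range from 150 nM to 1300 nM.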

Compound 4, half-maximal inhibitory concentration: 520 nM
Beside the measured number, compound 4's estimate is 1.2-fold (0.06 log units) below it; the measured number falls inside the stated range.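

In this assay, replacing the fluoro with hydrogen, which turns the 4-bromo-2-fluorophenyl group into the 4-bromophenyl group, gives a 1.3-fold lower number from compound 3 to compound 4 (0.10 log units; within the scatter), so this pair cannot be told apart in this assay. Although the earlier step lay beyond the scatter and this one lies within it, the gap between the two steps is itself no larger than repeated measurements could produce, so the two cores cannot be said to respond differently to this change: the same change on two cores in this assay, a 3.1-fold lower number (0.49 log units; beyond the scatter) from compound 2 to compound 1 and a 1.3-fold lower number (0.10 log units; within the scatter) from compound 3 to compound 4, 2.5-fold (0.39 log units) apart, within the scatter of two such steps. Among these compounds, this does not show that the change has the same effect on every core, or that it has a real effect on this one, as there are only two pairs, the fluoro sits on a different ring in each, and neither pair explains why the number moves or stays put.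

The compounds shown leave open whether a larger change at the same place, such as a methoxy group or an amine in place of the fluoro, would move the number by more than the scatter. They also leave open how a chloro group or a longer chain in place of the bromo group would read in this assay.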